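Series notes: trifluoromethoxy for trifluoromethyl on the pendant ring

The source may report more compounds than this note shows. Statements on the series, on what has been measured and on what is new or still open speak of the compounds shown alone.

For the measured compounds named here, compound 2 `Oc1ccc(-c2cc(-c3ccccc3C(F)(F)F)cc(-c3cccc(O)c3)n2)cc1` stands highest of the two numbers measured so far in a functional assay on HeLa cells (Homo sapiens) for inhibition; on this read-out lower numbers stand for stronger inhibition and higher numbers for weaker inhibition. Its nearest neighbour is compound 1 `Oc1ccc(-c2cc(-c3cccc(F)c3)cc(-c3cccc(O)c3)n2)cc1`, for which compound 1 gives 14200 nM in this assay, while compound 2 gives 17400 nM; the step of a 1.2-fold higher number from compound 1 to compound 2 (0.09 log units; within the scatter) is within the scatter. Compound 3 `Oc1ccc(-c2cc(-c3ccccc3OC(F)(F)F)cc(-c3cccc(O)c3)n2)cc1` is not yet measured. It differs from compound 2 by trifluoromethoxy in place of trifluoromethyl on an aromatic carbon. Going by the values given here, no measured step touches this exact exchange; the only step known, from compound 1 to compound 2, is a different change on the same pendant ring and moved the number within the scatter. With nothing more to go on, no step beyond the scatter in this assay is expected for compound 3, so the estimated step of a 1.0-fold lower number from compound 2 to compound 3 (0.01 log units; within the scatter) is small. Compound 3 is estimated at 17000 nM, with a range from 7000 nM to 42000 nM.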

Compound 3, half-maximal inhibitory concentration: 5800 nM
Compound 3: the middle estimate sits 2.9-fold (0.47 log units) above what was measured; the whole stated range lies above it.
By their numbers in this assay, from the lowest: compound 3; then compounds 1 and 2 (each within the scatter of the next).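

In this assay, for the compounds shown here, the place ortho to a large group on the pendant ring proves responsive: trifluoromethoxy in place of trifluoromethyl gives a 3.0-fold lower number from compound 2 to compound 3 (0.48 log units; beyond the scatter) and so provides the first step beyond the scatter. The earlier change on this ring, a 1.2-fold higher number from compound 1 to compound 2 (0.09 log units; within the scatter), did not separate its two compounds, so the series now shows that a single exchange on this ring can move the number. No evidence is at hand that accounts for the lower number with this exchange.

From the compounds shown here alone, whether the lower number follows the added oxygen or the trifluoromethoxy group as a whole stays open, and a methoxy group or an amine on the same aromatic carbon would bear on that. Also open, going by these compounds, is whether the same exchange would give a similar step at another place on the pendant ring.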